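Removing the pyrazole nitrogen methyl in the oxadiazole amine series

The source may hold more compounds than are shown below. What is called first, only, known or untested is meant among the compounds shown, and "the series" means these compounds.

Measured compounds in an assay on COS-7 cells for inhibition of tyrosine-protein kinase receptor UFO (Homo sapiens), read by ELISA, with a stated time of 1 h; on this read-out lower numbers stand for stronger inhibition and higher numbers for weaker inhibition:
compound 1 `Cc1nn(C)c(C)c1-c1ccc(-c2nnc(N(C)Cc3ccc4nccn4c3)o2)cc1` gives 3160 nM.
compound 2 `Cc1cc(-c2c(C)nn(C)c2C)ccc1-c1nnc(N(C)Cc2ccc3nccn3c2)o1` gives 398 nM.
compound 3 `Cc1nn(C)c(C)c1-c1ccc(-c2nnc(N(C)Cc3ccc4nccn4c3)o2)c(C#N)c1` gives only a limit, > 31600 nM.

Compound 2 holds the lowest of the two numbers reported in this assay. Its nearest neighbour is compound 1, and the step of a 7.9-fold lower number from compound 1 to compound 2 (0.90 log units; beyond the scatter) comes from a methyl in place of hydrogen on an aromatic carbon. The value of compound 3 is a limit of the assay, not a number. The steps of an at least 10-fold higher number from compound 1 to compound 3 (1.00 log units; beyond the scatter) and an at least 79-fold higher number from compound 2 to compound 3 (1.89 log units; beyond the scatter) both come from a cyano entering on an aromatic carbon.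

Compound 4 `Cc1cc(-c2c(C)n[nH]c2C)ccc1-c1nnc(N(C)Cc2ccc3nccn3c2)o1` differs from compound 2 by hydrogen in place of methyl on an aromatic nitrogen. For the measured compounds named here, none of the measured steps touches this ring nitrogen; all three concern substituents on the aromatic carbons of the neighbouring benzene, so they give no direct guide to this change. With the remainder of the structure of compound 2 retained, the expectation is a step of a 1.3-fold higher number from compound 2 to compound 4 (0.10 log units; within the scatter), within or close to the scatter, in either direction. Compound 4 is therefore estimated at 500 nM in this assay, with a range from 150 nM to 1600 nM.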

Compound 4, half-maximal inhibitory concentration: 15800 nM
Estimate against measurement, compound 4: 32-fold (1.50 log units) below; the measured number lies above the stated range.
By their numbers in this assay, from the lowest: compound 2; then compound 1; then compound 4. At a limit, above all of these: compound 3.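

In this assay, the methyl on the aromatic nitrogen of the 1,3,5-trimethyl-1H-pyrazol-4-yl group proves far from neutral: replacing it with hydrogen gives a 40-fold higher number from compound 2 to compound 4 (1.60 log units; beyond the scatter). For the compounds shown here, this is the first change on the five-membered aromatic ring with 2 nitrogen, and it shows that the number responds strongly there, whereas the earlier steps only concerned substituents on aromatic carbons of the other ring. The compounds shown give no measured property that would explain this step, so its cause remains unassigned.

Going by these compounds alone, the loss is seen only with the rest of compound 2 in place, so whether hydrogen on this nitrogen has a similar effect in the core of compound 1, without the added aromatic methyl, remains open. Also open is whether the methyl is the best group at this nitrogen or just better than hydrogen, since the compounds shown say nothing about an ethyl group, a longer chain or a chain ending in an amine or a carboxylic acid there.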